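The compounds below may be only part of what the source reports. "The series", "measured", "known", "first", "only" and "open" are said of these compounds alone.

Measured so far:
compound 1, `N=C(N)N/N=C/c1c(-c2cccs2)nc2sccn12`, 28800 nM
compound 2, `Cc1cn2c(/C=N/NC(=N)N)c(-c3cccs3)nc2s1`, 5890 nM

Within the data shown here, in a functional assay on cells (Melanoma cell, Homo sapiens) for inhibition (on this read-out higher numbers stand for weaker inhibition of growth and lower numbers for stronger inhibition of growth), compound 2 gives 5890 nM, the lower of the two numbers; the only other measured compound, compound 1, stands a 4.9-fold lower number from compound 1 to compound 2 (0.69 log units; beyond the scatter) apart from it. Among the measured compounds shown here, that step, methyl in place of hydrogen on an aromatic carbon, is the one measured step, and it was modest but beyond the scatter.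

Compound 3, `Cc1cc(-c2nc3sc(C)cn3c2/C=N/NC(=N)N)c(C)s1`, differs from compound 2 by 2,5-dimethylthiophen-3-yl in place of thiophen-2-yl on an aromatic carbon. For the measured compounds named here, no measured step touches that group, so the step from compound 1 to compound 2 bears on it only loosely, as a sign that added methyls on this core were tolerated. The step expected in this assay for compound 3 is therefore a 1.3-fold lower number from compound 2 to compound 3 (0.12 log units; within the scatter), not beyond the scatter in either direction. Compound 3 is estimated at 4500 nM, between 1200 nM and 16000 nM.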

Compound 3, concentration for total growth inhibition: 15100 nM
For compound 3 the middle estimate is 3.4-fold (0.53 log units) below the measured one; measured number inside the range.
By their numbers in this assay, from the lowest: compound 2; then compounds 3 and 1 (each within the scatter of the next).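

Among these compounds, at the aromatic carbon that carries the thiophene, which no earlier step had touched, this assay responds to this exchange: with 2,5-dimethylthiophen-3-yl in place of thiophen-2-yl there is a 2.6-fold higher number from compound 2 to compound 3 (0.41 log units; beyond the scatter), a modest step towards weaker inhibition of growth. The methyl that gave a 4.9-fold lower number from compound 1 to compound 2 (0.69 log units; beyond the scatter) at another place on the shared core therefore offers no general rule that added methyls strengthen inhibition of growth, and compound 3 is the case that goes against such a reading. Nothing available here accounts for the direction of this step.

The compounds shown leave open whether the two methyls or the change from a thiophen-2-yl to a thiophen-3-yl attachment carries the step, as both change together in compound 3. They also leave open how a plain phenyl ring or an amine at this carbon would read in this assay.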